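The compounds below may be only part of what the source reports. "The series", "measured", "known", "first", "only" and "open" are said of these compounds alone.

Of the compounds shown here, three have so far been tested in a functional assay on HT-29 cells (Homo sapiens) for antiproliferative activity, read by sulforhodamine B assay, with a stated time of 72 h; on this read-out higher numbers stand for weaker inhibition and lower numbers for stronger inhibition. Compound 1 `CN(C)C(=S)N/N=C/c1cc2cccnc2s1` gives 13400 nM in this assay. Compound 2 `CN(C)C(=S)N/N=C/c1ccc2cccnc2n1` gives 410 nM in this assay. Compound 3 `S=C(NCc1ccccc1)N/N=C/c1ccc2ccccc2n1` gives 75700 nM in this assay, the highest of the three numbers and therefore the weakest inhibition of the set: its gap to compound 1 and its gap to compound 2 both lie beyond the usual scatter of repeated measurements.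

Compound 4 `Cc1ccccc1NC(=S)N/N=C/c1ccc2ccccc2n1` has not yet been measured. It differs from compound 3 in a single place, with the same atoms joined differently: 2-methylphenyl in place of benzyl on an amide-type nitrogen. Among the compounds with values here, no pair of measured compounds shows this particular change, so there is no measured step to lean on, and the direction can only be guessed. Compound 4 is expected to give 30000 nM in this assay, with a likely range from 6000 nM to 150000 nM. The expected step is a 2.5-fold lower number from compound 3 to compound 4 (0.40 log units; beyond the scatter), a modest move toward a lower number that may yet turn out to fall within the scatter.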

Compound 4, half-maximal inhibitory concentration: 42300 nM
For compound 4 the middle estimate is 1.4-fold (0.15 log units) below the measured one; measured number inside the range.
By their numbers in this assay, from the lowest: compound 2; then compound 1; then compounds 4 and 3 (each within the scatter of the next).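

In this assay the exchange of benzyl for 2-methylphenyl on the amide-type nitrogen comes to a 1.8-fold lower number from compound 3 to compound 4 (0.25 log units; within the scatter) and so gives no readable difference between the two compounds. Within the data shown here, this is the first measured step at this position, and it shows that rearranging the same seven carbon atoms of this group leaves compound 3 and compound 4 indistinguishable on this read-out. No measurement is at hand that could explain this result.

Among these compounds, with only this one step, it remains open whether a different kind of group at this nitrogen, such as a longer alkyl chain or a chain ending in an amine or a carboxylic acid, would give a number clearly apart from these two. Compound 1 and compound 2 differ from compound 3 and compound 4 in more than one place, so what sets their numbers apart cannot be read from these data.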